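Swapping a trimethoxyphenyl for thiophene on a linker-extended chalcone

This account rests on a few compounds, and the source may have more. Where it says the series, first, only, none or still open, it means among the compounds named here.

Measured compounds:
compound 1 `COc1cc(/C=C/C(=O)/C=C/c2cccs2)ccc1OCc1cn(CCOc2cc(=O)oc3ccccc23)nn1`: 71%
compound 2 `COc1cc(/C=C/C(=O)/C=C/c2cc(OC)c(OC)c(OC)c2)ccc1OCc1cn(CCOc2cc(=O)oc3ccccc23)nn1`: 89%
compound 3 `COc1cc(/C=C/C(=O)/C=C/c2cc(OC)c(OC)c(OC)c2)ccc1OCc1cn(CCCCOc2cc(=O)oc3ccccc23)nn1`: 63%

All three were tested in a functional assay on HCT-116 cells (Homo sapiens) for inhibition, read by sulforhodamine B assay, with a stated time of 48 h, tested at 50 uM; on this read-out higher numbers stand for more inhibition of growth at the one concentration tested and lower numbers for less inhibition of growth. Compound 2 gives 89%, and compound 1, which carries thiophen-2-yl in place of 3,4,5-trimethoxyphenyl on a double-bonded chain carbon bound to a double-bonded chain carbon, gives 71%; the step is a number 18 percentage points lower from compound 2 to compound 1 (beyond the scatter). Compound 3 gives 63%. How the core of compound 3 differs from the core of compound 2 is not broken down here.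

Compound 4 `COc1cc(/C=C/C(=O)/C=C/c2cccs2)ccc1OCc1cn(CCCCOc2cc(=O)oc3ccccc23)nn1` is not yet measured. It stands to compound 3 as compound 1 stands to compound 2, carrying (thiophen-2-yl in place of 3,4,5-trimethoxyphenyl on a double-bonded chain carbon bound to a double-bonded chain carbon), so the same change is made twice among these compounds. Because the earlier step was a number 18 percentage points lower from compound 2 to compound 1 (beyond the scatter), the account expects a step of similar size here, the estimate for a number 18 percentage points lower from compound 3 to compound 4 (beyond the scatter) resting on that single measured pair. Compound 4 is therefore expected to give about 45% in this assay, with a plausible range from 30% to 60%.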

Compound 4, percent growth inhibition at one concentration: 41%
For compound 4 the middle estimate is 4 percentage points above the measured one; the measured number falls inside the stated range.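

In this assay, the step for thiophen-2-yl in place of 3,4,5-trimethoxyphenyl on the second core is a number 22 percentage points lower from compound 3 to compound 4 (beyond the scatter). Set beside the earlier step, the change carries over from one core to the other at much the same size: the same change on two cores in this assay, a number 18 percentage points lower (beyond the scatter) from compound 2 to compound 1 and a number 22 percentage points lower (beyond the scatter) from compound 3 to compound 4, 4 percentage points apart, within the scatter of two such steps. Among the compounds shown here, this agreement rests on only two matched pairs, each read at a single concentration in one cell line, so it shows that the change behaves alike on these two cores but does not show that it would do so on any other core or at other concentrations.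

The compounds shown leave open whether an unsubstituted phenyl, a furan-2-yl or a pyridinyl group on a double-bonded chain carbon bound to a double-bonded chain carbon would give a similar step. They also leave open whether the step would hold on a core with a longer chain.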